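Halogen swap on the pendant phenyl across two cores

The source may hold more compounds than are shown below. What is called first, only, known or untested is meant among the compounds shown, and "the series" means these compounds.

Compound 1 `CCn1cc(-c2ccc(F)cc2)c(=O)c2cc(F)c(N3CCNCC3)cc21` carries a 4-fluorophenyl group, and compound 2 `CCn1cc(-c2ccc(Cl)cc2)c(=O)c2cc(F)c(N3CCNCC3)cc21` is its 4-chlorophenyl counterpart; the two differ only by chloro in place of fluoro on an aromatic carbon. In a functional assay on A549 cells (Homo sapiens) for antiproliferative activity, read by MTT assay, with a stated time of 48 h (a lower number here means a stronger inhibitor, a higher number a weaker inhibitor), compound 1 gives 11400 nM, while compound 2 gives 1250 nM, so that the step of a 9.1-fold lower number from compound 1 to compound 2 (0.96 log units; beyond the scatter).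

Compound 3 `O=c1c(-c2cccc(F)c2)cn(C2CC2)c2cc(N3CCNCC3)c(F)cc12` sits on a second core and carries a 3-fluorophenyl group; the difference between the two cores is not broken down here. In this assay compound 3 gives 1100 nM, a number close to that of compound 2 and well away from that of compound 1.

Compound 4 `O=c1c(-c2cccc(Cl)c2)cn(C2CC2)c2cc(N3CCNCC3)c(F)cc12` has not been measured. It differs from compound 3 by chloro in place of fluoro on an aromatic carbon. Within the data shown here, this is the same kind of change as the one from compound 1 to compound 2, but not the same: there the chloro enters para to a large group, here it enters meta to a large group, and the surrounding core is different. Because the measured precedent a 9.1-fold lower number from compound 1 to compound 2 (0.96 log units; beyond the scatter) was made at a different place, only part of that step is expected to carry over, with the direction kept.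

For compound 4 the step of a 2.8-fold lower number from compound 3 to compound 4 (0.44 log units; beyond the scatter) is expected in this assay. Compound 4 is estimated at 400 nM, with the likely range from 150 nM to 1100 nM.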

Compound 4, half-maximal inhibitory concentration: 110 nM
Estimate against measurement, compound 4: 3.6-fold (0.56 log units) above, and the stated range ends above it.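

In this assay, chloro in place of fluoro on the pendant phenyl ring, here 3-fluorophenyl to 3-chlorophenyl, gives a 10-fold lower number from compound 3 to compound 4 (1.00 log units; beyond the scatter), so the change keeps both its direction and its size on the second core rather than only part of the earlier step carrying over. The two steps in this series do not differ beyond what repeated measurement would give: the same change on two cores in this assay, a 9.1-fold lower number (0.96 log units; beyond the scatter) from compound 1 to compound 2 and a 10-fold lower number (1.00 log units; beyond the scatter) from compound 3 to compound 4, 1.1-fold (0.04 log units) apart, within the scatter of two such steps This shows that, for these two pairs, the gain from the swap did not depend on the combination of core and halogen place, but it rests on two pairs only, in one cell line, and the pairs differ in core and in halogen place at once, so neither factor is tested alone and no cause for the step can be drawn from these numbers.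

Open is whether the step keeps its size when the halogen place is held fixed and only the core changes, since no pair shown isolates that comparison. Also open, as far as these compounds go, is whether bromo or methyl on the same carbon would extend the trend seen with chloro, or whether it holds only for the fluoro to chloro swap.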